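Meta-fluoro added to the phenyl of compound 2

The compounds below may be only part of what the source reports. "The series", "measured", "known", "first", "only" and "open" are said of these compounds alone.

Two compounds have numbers in an assay on HEK293 cells for positive allosteric modulation of metabotropic glutamate receptor 5 (Homo sapiens), read by FLIPR; a higher number here means that more compound is needed for the effect, a lower number that less compound is needed. Compound 1 `O=C(c1ccc(Cl)cc1)N1CC(c2nc(-c3cccc(F)c3)no2)C1` gives 2500 nM in this assay. Compound 2 `O=C([C@@H]1CC2CCC1C2)N1CC(c2nc(-c3ccccc3)no2)C1` gives 400 nM in this assay, the lower of the two numbers, with compound 1 standing beyond the scatter above it. Compound 3 `O=C([C@@H]1CC2CCC1C2)N1CC(c2nc(-c3cccc(F)c3)no2)C1` differs from compound 2 by fluoro in place of hydrogen on an aromatic carbon. Within the data shown here, no measured pair isolates this change, and the step is expected to stay within the scatter, in no firm direction. Compound 3 is accordingly expected near 300 nM, in the range 100 nM to 1000 nM. The expected step is a 1.3-fold lower number from compound 2 to compound 3 (0.12 log units; within the scatter).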

Compound 3, half-maximal effective concentration: 100 nM
The estimate for compound 3 lay 3.0-fold (0.48 log units) above the measured number; measured number inside the range.
By their numbers in this assay, from the lowest: compound 3; then compound 2; then compound 1.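

In this assay, among these compounds, phenyl to 3-fluorophenyl gives a 4.0-fold lower number from compound 2 to compound 3 (0.60 log units; beyond the scatter) and is the first matched reading at this position, showing that the aromatic ring responds to a single fluoro here. With 3-fluorophenyl held constant, the group on the carbonyl carbon accounts for a 25-fold lower number from compound 1 to compound 3 (1.40 log units; beyond the scatter) as a large step in its own right. No supporting data bear on why either step arises.
Still open, going by these compounds, is whether chloro or methoxy in this place would follow fluoro, and whether fluoro on the other aromatic carbons would give a similar step.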